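A Bromo Substituent on the Sulfonyl Phenyl of Compound 3

The source may report more compounds than this note shows. Statements on the series, on what has been measured and on what is new or still open speak of the compounds shown alone.

Measured compounds:
compound 1 `COc1cc(Nc2nc3ccccc3nc2S(=O)(=O)c2ccccc2)cc(OC)c1` — 950 nM
compound 2 `O=S(=O)(c1ccccc1)c1nc2ccccc2nc1Nc1ccc(F)cc1` — 5190 nM
compound 3 `O=S(=O)(c1ccccc1)c1nc2ccccc2nc1Nc1ccc(C(F)(F)F)cc1` — 2090 nM

Three compounds share one core, each carrying a phenylsulfonyl group and an arylamino group, and each has been tested in a functional assay on HCT-116 cells (Homo sapiens) for cytotoxicity, read by MTT assay, with a stated time of 72 h; a higher number here means a weaker inhibitor, a lower number a stronger inhibitor. In this assay compound 1 gives 950 nM, compound 2 gives 5190 nM and compound 3 gives 2090 nM. Compound 3 thus holds the second highest of the three numbers: a 2.2-fold higher number from compound 1 to compound 3 (0.34 log units; beyond the scatter), while a 2.5-fold lower number from compound 2 to compound 3 (0.40 log units; beyond the scatter).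

Compound 4 `O=S(=O)(c1ccc(Br)cc1)c1nc2ccccc2nc1Nc1ccc(C(F)(F)F)cc1` is the next compound in the series. Its difference from compound 3 is bromo in place of hydrogen on an aromatic carbon.

Among the measured compounds shown here, every measured step so far concerns the ring on the amine nitrogen: a 5.5-fold higher number from compound 1 to compound 2 (0.74 log units; beyond the scatter), a 2.2-fold higher number from compound 1 to compound 3 (0.34 log units; beyond the scatter) and a 2.5-fold lower number from compound 2 to compound 3 (0.40 log units; beyond the scatter). For the measured compounds named here, none of these touches the phenylsulfonyl ring, so no measured step bears directly on the change from compound 3 to compound 4. The account therefore carries no evidence for a shift in either direction, and the expected step is one of no size beyond the scatter, a 1.0-fold lower number from compound 3 to compound 4 (0.02 log units; within the scatter), with a widened range to reflect the untested position. On that basis compound 4 is estimated at 2000 nM, expected between 800 nM and 5000 nM.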

Compound 4, half-maximal inhibitory concentration: 2610 nM
For compound 4 the middle estimate is 1.3-fold (0.12 log units) below the measured one; the measured number falls inside the stated range.
By their numbers in this assay, from the lowest: compound 1; then compounds 3, 4 and 2 (each within the scatter of the next, the first and the last beyond it).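

In this assay, among the compounds shown here, the step of a 1.2-fold higher number from compound 3 to compound 4 (0.10 log units; within the scatter) is the first measured change on the phenylsulfonyl ring, and it leaves the two compounds indistinguishable: a bromo group on this aromatic carbon, para to a large group, yields no step beyond the scatter. The earlier compounds shown here could speak only to the ring on the amine nitrogen, where replacing 3,5-dimethoxyphenyl with 4-fluorophenyl gave a 5.5-fold higher number from compound 1 to compound 2 (0.74 log units; beyond the scatter); this single result shows that the phenyl of the phenylsulfonyl group can carry one bromine atom at this carbon without a readable step, at least with the 4-(trifluoromethyl)phenyl group on the nitrogen. Nothing available here offers a measured explanation for this result.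

The compounds shown leave open whether a different group on the same carbon, such as an amine or a carboxylic acid, would give a step beyond the scatter, since bromo is the only replacement for hydrogen here. They also leave open whether the same bromo group would give a similar result with the 3,5-dimethoxyphenyl or 4-fluorophenyl group on the nitrogen.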